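This account rests on a few compounds, and the source may have more. Where it says the series, first, only, none or still open, it means among the compounds named here.

In an ADME assay (Rattus norvegicus, strain Wistar Han) for pharmacokinetics (a higher number here means that more of the compound sits outside the plasma, a lower number that more of the compound stays in the plasma), compound 1 (`CCn1c(-c2cnc(C)nc2)nc2c(N[C@H]3CCN(C(=O)C4CCOC4)C3)ncnc21`) gives 0.7 L/kg and compound 2 (`CCn1c(-c2cnc(C)nc2)nc2c(O[C@H]3CCN(C(=O)N4CC(OC)C4)C3)ncnc21`) gives 0.4 L/kg on the same scale. Among the measured compounds shown here, these two numbers lie within the scatter of each other, so compound 1 stands level with the only other measured compound. Compound 3 (`CCn1c(-c2cnc(C)nc2)nc2c(N[C@H]3CCN(C(=O)C4CC4)C3)ncnc21`) keeps the core of compound 1 and changes one group: cyclopropyl in place of oxolan-3-yl on a carbonyl carbon with cyclopropyl in place of oxolan-3-yl on a carbonyl carbon. For the measured compounds named here, no measured pair isolates this change, so nothing fixes its size. A modest upward move in this assay is expected, and a 1.3-fold higher number from compound 1 to compound 3 (0.11 log units; within the scatter) is estimated to stay within or close to the scatter. The expectation stays anchored on compound 1 at 0.7 L/kg as the closest measured structure. For compound 3 the estimated value is 0.9 L/kg with an expected range from 0.5 L/kg to 1.6 L/kg in repeat measurements.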

Compound 3, volume of distribution: 1 L/kg
Estimate against measurement, compound 3: 1.1-fold (0.05 log units) below; the measured number falls inside the stated range.
By their numbers in this assay, from the lowest: compounds 2, 1 and 3 (each within the scatter of the next, the first and the last beyond it).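

On the carbonyl carbon whose other neighbour is the amide-type nitrogen in a ring, cyclopropyl in place of oxolan-3-yl gives the series its first reading of a single change in this assay: a 1.4-fold higher number from compound 1 to compound 3 (0.15 log units; within the scatter). In this one pair, the exchange of the five-membered ring and its hydrogen-bond acceptor for the three-membered carbon ring therefore leaves the read-out within the scatter, so no effect of the swap can be resolved. No supporting evidence bears on this step.

From the compounds shown here alone, whether an amine, a carboxylic acid or a longer alkyl chain on the same carbonyl carbon would take this assay beyond the scatter remains open. With a single pair at this position, it is also unknown whether the same swap would give a similar step on a different core.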